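The source may report more compounds than this note shows. Statements on the series, on what has been measured and on what is new or still open speak of the compounds shown alone.

Compound 1 `CN1CCCC1CCn1nc(Cc2ccc(Cl)cc2)c2ccccc2c1=O` gives 316 nM in an assay for binding affinity to Alpha-1B adrenergic receptor (Homo sapiens); on this read-out lower numbers stand for stronger inhibition and higher numbers for weaker inhibition; compound 2 `CN1CCC(Cn2nc(Cc3ccc(Cl)cc3)c3ccccc3c2=O)C1` gives 79.4 nM; compound 3 `CN(C)CCCn1nc(Cc2ccc(Cl)cc2)c2ccccc2c1=O` gives 316 nM, level with compound 1 at the digits printed, the two together the highest of the three numbers, with compound 2 the furthest from compound 3. The steps among them: a 4.0-fold lower number from compound 1 to compound 2 (0.60 log units; beyond the scatter), no change at the digits printed from compound 1 to compound 3 (within the scatter), a 4.0-fold higher number from compound 2 to compound 3 (0.60 log units; beyond the scatter).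

Compound 4 `CN1CCC(n2nc(Cc3ccc(Cl)cc3)c3ccccc3c2=O)CC1` differs from compound 3 in one place: 1-methylpiperidin-4-yl in place of 3-(dimethylamino)propyl on an aromatic nitrogen, on an aromatic nitrogen of a six-membered aromatic ring with 2 nitrogen, part of a fused or bridged system of two rings.

The bearing steps are those in which an open chain and a ring bound directly to the aromatic nitrogen exchange: a 4.0-fold lower number from compound 1 to compound 2 (0.60 log units; beyond the scatter) and a 4.0-fold higher number from compound 2 to compound 3 (0.60 log units; beyond the scatter), each modest, each favouring the ring bound directly to the aromatic nitrogen. The change from compound 3 to compound 4 is of that kind, so a modest step towards a lower number in this assay is expected, a 3.2-fold lower number from compound 3 to compound 4 (0.50 log units; beyond the scatter). Compound 4 is therefore estimated at 100 nM, with a range from 40 nM to 250 nM.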

Compound 4, inhibition constant: 6.31 nM
Compound 4: the middle estimate sits 16-fold (1.20 log units) above what was measured; the whole stated range lies above it.
By their numbers in this assay, from the lowest: compound 4; then compound 2; then compounds 1 and 3 (each within the scatter of the next).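

In this assay, going by these compounds alone, the side chain on the aromatic nitrogen turns out to matter far more than the earlier compounds suggested, with a 50-fold lower number from compound 3 to compound 4 (1.70 log units; beyond the scatter) and a 50-fold lower number from compound 1 to compound 4 (1.70 log units; beyond the scatter) and also a 13-fold lower number from compound 2 to compound 4 (1.10 log units; beyond the scatter) all large, which makes compound 4 the strongest of the four. Compounds 1 and 2 also carry a saturated ring with a methylated nitrogen, so a ring alone does not set compound 4 apart; among the compounds shown, only the 1-methylpiperidin-4-yl group places its ring straight on the aromatic nitrogen. Nothing available here accounts for the size of these steps.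

On these data alone, it remains open whether ring size or the direct attachment carries the gain, which 1-methylpyrrolidin-3-yl on the same aromatic nitrogen would help to separate. As far as these compounds go, the role of the methyl group is also open, and the unsubstituted piperidin-4-yl group would test it.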